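A few compounds are considered here, and "the series" means these few. Any claim that something is new, unique, unknown or untested is made for them only; others in the source may bear on it.

Compound 1 `Cc1nc2c(OCc3ccccc3)cccn2c1NC=O`: 3%
Compound 2 `Cc1nc2c(OCc3ccccc3)cccn2c1/N=C/N(C)C`: 12%

In a functional assay on the whole organism with Canis familiaris (Canis lupus familiaris) as the target, at a dose of 2 mg/kg by the intravenous route (on this read-out lower numbers stand for a weaker effect and higher numbers for a stronger effect at the one dose given), compound 2 stands highest of the two numbers, a standing the scatter does not secure: a number 9 percentage points higher from compound 1 to compound 2 (within the scatter). Compound 3 `CCNc1c(C)nc2c(OCc3ccccc3)cccn12` differs from compound 2 in one place: a group of 3 heavy atoms (2 carbon, 1 nitrogen; no ring) in place of a group of 5 heavy atoms (3 carbon, 2 nitrogen; no ring), on an aromatic carbon. For the measured compounds named here, the only measured step that bears on this is the exchange on the same aromatic carbon, a number 9 percentage points higher from compound 1 to compound 2 (within the scatter), which stayed within the scatter. A step of comparably small size is therefore expected, a number 4 percentage points lower from compound 2 to compound 3 (within the scatter), with no direction that would clear the scatter. Compound 3 is estimated at 8%, between 0% and 25%.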

Compound 3, a percentage reported as inhibition, in the whole organism at one dose (the size of the read-out at that dose, not a potency): 32%
Compound 3: middle estimate off by 24 percentage points, on the low side; the whole stated range lies below it.
By their numbers in this assay, from the lowest: compounds 1 and 2 (each within the scatter of the next); then compound 3.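

In this assay the group on this aromatic carbon turns out to matter: ethylamino in place of the larger open-chain group gives a number 20 percentage points higher from compound 2 to compound 3 (beyond the scatter), and ethyl in place of formyl on the same nitrogen gives a number 29 percentage points higher from compound 1 to compound 3 (beyond the scatter). Of the three compounds, only compound 3 stands clear of the others, so a change here can shift the effect at the one dose given. Nothing at hand explains this rise. As far as these compounds go, whether a longer chain such as propyl on this nitrogen, or a free amine, would raise the effect further remains open.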